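Compound 3: 2,4-dichlorophenyl replacing 4-bromophenyl

This account rests on a few compounds, and the source may have more. Where it says the series, first, only, none or still open, it means among the compounds named here.

Within the data shown here, in a functional assay on THP-1 cells (Homo sapiens) for cytotoxicity, read by MTT assay, with a stated time of 24 h (a lower number here means a stronger inhibitor, a higher number a weaker inhibitor), compound 1 (`CN1C/C(=C\c2cccc([N+](=O)[O-])c2)C(=O)/C(=C/c2ccc(Cl)cc2Cl)C1`) gives 3560 nM and compound 2 (`CN1C/C(=C\c2ccc(Br)cc2)C(=O)/C(=C/c2ccc(C#N)cc2)C1`) gives 4400 nM as the only two numbers so far, and these lie within the scatter of each other. The two compounds differ in more than one place, so no single change has yet been measured. Compound 3 (`CN1C/C(=C\c2ccc(C#N)cc2)C(=O)/C(=C/c2ccc(Cl)cc2Cl)C1`) differs from compound 2 by 2,4-dichlorophenyl in place of 4-bromophenyl on a double-bonded chain carbon bound to a double-bonded ring carbon. The 2,4-dichlorophenyl group also occurs in compound 1 at 3560 nM in this assay and gives no hint of a large shift. The expected step, a 1.3-fold lower number from compound 2 to compound 3 (0.10 log units; within the scatter) in this assay, is small and within the scatter, with no firm direction. Compound 3 is estimated at 3500 nM with an expected range from 1500 nM to 8000 nM in this assay for this measurement.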

Compound 3, half-maximal inhibitory concentration: 1910 nM
The estimate for compound 3 lay 1.8-fold (0.26 log units) above the measured number; measured number inside the range.
By their numbers in this assay, from the lowest: compounds 3, 1 and 2 (each within the scatter of the next, the first and the last beyond it).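

In this assay, among these compounds, the first single-place change on a double-bonded chain carbon bound to a double-bonded ring carbon, 2,4-dichlorophenyl in place of 4-bromophenyl, gives a 2.3-fold lower number from compound 2 to compound 3 (0.36 log units; beyond the scatter) with 4-cyanophenyl held on the other side, a modest step. With 2,4-dichlorophenyl held instead, 4-cyanophenyl in place of 3-nitrophenyl gives a 1.9-fold lower number from compound 1 to compound 3 (0.27 log units; within the scatter) and stays inside the scatter, so these two groups are not told apart in this series. No measurement shown here bears on the reason for either step.

The step from 4-bromophenyl to 2,4-dichlorophenyl alters both the halogen and the substitution pattern, and a 4-chlorophenyl or 2-chlorophenyl analogue would be needed to separate the two. The compounds shown also leave open how a group such as an amine or a carboxylic acid on the phenyl ring would read, and what a longer chain in place of the methyl on the shared core would do.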